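Two Measured Compounds and One Awaiting Its Value

The source may report more compounds than this note shows. Statements on the series, on what has been measured and on what is new or still open speak of the compounds shown alone.

compound 1 `COc1ccc(Cl)cc1N1CCN(C(=O)c2oc(C)nc2-c2ccccc2F)CC1`: 153 nM
compound 2 `CC(=O)c1ccc(N2CCN(C(=O)c3oc(C)nc3-c3ccccc3)CC2)cc1`: "not active" (no number reported)

In a functional assay on HL-60 cells (Homo sapiens) for inhibition, read by MTT assay, with a stated time of 72 h (on this read-out higher numbers stand for weaker inhibition and lower numbers for stronger inhibition), compound 1 gives 153 nM. In this assay compound 2 gives "not active" (no number reported), so no single number marks where compound 2 stands; it is described only as inactive, and nothing can be said of how far it lies from compound 1 beyond that the two are not alike. Among the compounds with values here, no step between measured compounds is available for this pair, as the two structures differ in more than one place.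

Compound 3 `CC(=O)Nc1cccc(N2CCN(C(=O)c3oc(C)nc3-c3ccccc3)CC2)c1` has not been measured in this assay. Compared with compound 2 the change is 3-acetamidophenyl in place of 4-acetylphenyl on an amine nitrogen in a ring. The starting point carries no figure, so the size of the step cannot be expressed against a measured value; what is expected is that compound 3 stays weak in this assay, with little movement from an inactive start, and any apparent change would be hard to separate from the scatter. Compound 3 is therefore estimated at about 20000 nM in this assay, with a range from 3000 nM to 100000 nM, and a number may not be obtained at all.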

Compound 3, half-maximal inhibitory concentration: 329 nM
For compound 3 the middle estimate is 61-fold (1.78 log units) above the measured one; measured number below the stated range.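

In this assay, within the data shown here, compound 3 gives 329 nM, while compound 2 gives "not active" (no number reported), so no step from compound 2 to compound 3 can be read. The compounds shown leave open how far 3-acetamidophenyl in place of 4-acetylphenyl moves the read-out in numerical terms. Nothing available explains the result for compound 3.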